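The source may hold more compounds than are shown below. What is called first, only, known or untested is meant among the compounds shown, and "the series" means these compounds.

Measured so far in an ADME assay on microsomes from liver (Homo sapiens) for metabolic stability, read by LC-MS, using NADPH, with a stated time of 10 min, tested at 10 uM (a lower number here means that the compound disappears faster, a higher number that the compound lasts longer), and given as half-life:
- compound 1 `Nc1ncnc2c1c(Oc1cc(C(F)(F)F)ccn1)nn2[C@H]1CC[C@@H](CO)CC1` with 1.6 h
- compound 2 `Nc1ncnc2c1c(Oc1cc(O)ccn1)nn2C1CCC(F)(F)CC1` with > 2.41 h as a limit of the assay
- compound 3 `Nc1ncnc2c1c(Oc1cccc(Cl)c1)nn2[C@H]1C[C@H](F)C1` with 0.153 h as the lowest result

Only two of these results are plain numbers. Compound 1 holds the higher of them at 1.6 h and stands clear of the other. Compound 3 gives 0.153 h as that other number, and the gap between the two lies beyond the usual scatter of repeated measurements. Compound 2 gives > 2.41 h as a limit of the assay and not as a number.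

Still to be measured is compound 4 `Nc1ncnc2c1c(Oc1cc(C(F)(F)F)ccn1)nn2C1CCC(O)C1` and it stays close to compound 1. The change 3-hydroxycyclopentyl in place of 4-(hydroxymethyl)cyclohexyl on an aromatic nitrogen puts 3-hydroxycyclopentyl in place of 4-(hydroxymethyl)cyclohexyl on an aromatic nitrogen, and the shared core stays as it is.

Among the measured compounds shown here, the measured compounds differ from one another in more than one place, so no measured step speaks directly to this change. The best starting point is therefore compound 1 at 1.6 h in this assay and no shift beyond the scatter is expected in either direction. The estimated change a 1.1-fold lower number from compound 1 to compound 4 (0.06 log units; within the scatter) is expected to be small. Compound 4 is expected to give a half-life of 1.4 h (estimated range 0.6 h to 2.4 h).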

Compound 4, half-life: > 2.41 h
Compound 4: a limit, no number; the forecaster's own chance of this, stated with the estimate: 15%; at least 1.7-fold (0.23 log units) between middle value and limit.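

This result shows that, in this assay, the 3-hydroxycyclopentyl group on the aromatic nitrogen can take the place of 4-(hydroxymethyl)cyclohexyl with the half-life still reaching the top of the readable range, even though the five-membered ring replaces a six-membered one and the shared core stays the same. Compound 4 gives > 2.41 h, which is a limit of the assay and not a number. The change therefore has a floor but no upper end, an at least 1.5-fold higher number from compound 1 to compound 4 (0.17 log units; that floor lies within the scatter), and the real size of the step stays hidden at the ceiling of the read-out: the limit of > 2.41 h in this assay, at which 2 of the 4 values shown sit.

This single step changes the ring size and also moves the hydroxyl from a hydroxymethyl chain onto the ring itself, so the compounds shown cannot separate the two changes, and a 4-hydroxycyclohexyl or a 3-(hydroxymethyl)cyclopentyl group would be needed to tell them apart. They also leave open how this assay would respond if an amine or a carboxylic acid took the place of the hydroxyl on this ring at the same position on the aromatic nitrogen.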